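The source may hold more compounds than are shown below. What is called first, only, known or untested is meant among the compounds shown, and "the series" means these compounds.

Compound 3 `COc1cc(CNC(C)=O)ccc1F` is one of three closely related amides built on the shared core. In an assay on isolated protein for agonist activity at melatonin receptor type 1C (Xenopus laevis), read by spectrophotometry (a lower number here means that less compound is needed, a higher number that more compound is needed for the effect), compound 3 gives 2090 nM. Compound 1 `CCCC(=O)NCc1cc(OC)ccc1F` gives 1350 nM in this assay, and compound 2 `CCC(=O)NCc1ccc(OC)c(F)c1` gives 1050 nM; both gaps from compound 3 lie within the usual scatter, so the three numbers cannot be told apart. Compound 4 `CCCC(=O)NCc1ccc(F)c(OC)c1` has not yet been measured. It differs from compound 3 by ethyl in place of hydrogen on a saturated chain carbon bound to a carbonyl carbon. Going by the values given here, no pair of measured compounds isolates this change, and compounds 1 and 2, which carry the longer acyl chains, give numbers indistinguishable from compound 3. The step from compound 3 to compound 4 is therefore expected to be small, a 1.5-fold lower number from compound 3 to compound 4 (0.17 log units; within the scatter), and not beyond the scatter. For compound 4 the estimate is 1400 nM, with a range from 500 nM to 4000 nM.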

Compound 4, half-maximal effective concentration: 2510 nM
Compound 4: middle estimate off by 1.8-fold (0.25 log units), on the low side, within the range that was stated.
By their numbers in this assay, from the lowest: compounds 2, 1, 3 and 4 (each within the scatter of the next, the first and the last beyond it).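

Ethyl in place of hydrogen on a saturated chain carbon bound to a carbonyl carbon now has a direct reading: in this assay the change gives (a 1.2-fold higher number from compound 3 to compound 4 (0.08 log units; within the scatter)). Going from acetyl to propylcarbonyl with the rest of the molecule unchanged therefore leaves the number within the scatter, which the earlier compounds, differing in more than one place, could not show. No measured evidence here bears on why this position tolerates the change.

Going by these compounds, it remains open whether a longer chain, an amine or a carboxylic acid at this carbon would move the number beyond the scatter.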